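The source may report more compounds than this note shows. Statements on the series, on what has been measured and on what is new or still open speak of the compounds shown alone.

Measured in a functional assay on WI-38 VA13 cells (Homo sapiens) for cytotoxicity; on this read-out lower numbers stand for an effect already at smaller amounts and higher numbers for an effect only at larger amounts of compound:
Compound 1 `CNc1c(C(=O)c2ccccc2)sc2nc(-c3cccs3)ccc12`: 0.42 ug/mL
Compound 2 `COc1ccccc1C(=O)c1sc2nc(-c3cccs3)ccc2c1N`: 0.059 ug/mL
Compound 3 `COc1ccc(OC)c(C(=O)c2sc3nc(-c4cccs4)ccc3c2N)c1`: 0.079 ug/mL

Compound 2 sits at the low end of these numbers, in the same range as compound 3. Compound 1 lies clearly higher, but it differs from compound 2 in more than one place, so its value cannot be read as the effect of a single change.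

Compound 4 `CC(C)(C)C(=O)c1sc2nc(-c3cccs3)ccc2c1N` has not yet been measured. It carries tert-butyl in place of 2-methoxyphenyl on a carbonyl carbon.

For the measured compounds named here, only one measured step bears on this change, and only partly. Adding methoxy in place of hydrogen on an aromatic carbon gave a 1.3-fold higher number from compound 2 to compound 3 (0.13 log units; within the scatter), which shows that this one substitution on the ring left the read-out within the scatter. Every measured compound keeps an aromatic ring on the carbonyl, so none shows what happens when that ring is removed. Replacing the whole ring is a much larger change than adding a methoxy, so a moderate move towards a higher number is expected, with wide uncertainty. The expected change is a 3.4-fold higher number from compound 2 to compound 4 (0.53 log units; beyond the scatter). For compound 4 the estimate is 0.2 ug/mL, with an expected range from 0.05 ug/mL to 0.8 ug/mL.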

Compound 4, half-maximal effective concentration: 0.57 ug/mL
Beside the measured number, compound 4's estimate is 2.9-fold (0.45 log units) below it; the measured number falls inside the stated range.
By their numbers in this assay, from the lowest: compounds 2 and 3 (each within the scatter of the next); then compounds 1 and 4 (each within the scatter of the next).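

Swapping 2-methoxyphenyl for tert-butyl on the carbonyl carbon in this assay gives a 9.7-fold higher number from compound 2 to compound 4 (0.99 log units; beyond the scatter), a step clearly larger than the usual scatter and the first at this place that can be read as a real change. The earlier step, a 1.3-fold higher number from compound 2 to compound 3 (0.13 log units; within the scatter), only added a methoxy to the aromatic ring and stayed within the scatter, so it showed that one ring substitution could leave the number in place, while this new step shows that replacing the whole 2-methoxyphenyl group, ring included, does move it to a higher number. No measurement at hand offers an explanation for this rise.

This single swap removes the ring and the methoxy oxygen together and also brings in a smaller group, so the compounds shown cannot separate these parts of the change from one another. Going by these compounds, a cyclohexyl group on the same carbonyl carbon would keep a ring without an aromatic one, and a pyridyl ring or a small chain such as ethyl would test other replacements, so how much of the step belongs to the aromatic ring itself remains open.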